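The source may report more compounds than this note shows. Statements on the series, on what has been measured and on what is new or still open speak of the compounds shown alone.

Measured compounds in a functional assay on UACC-62 cells (Homo sapiens) for cytotoxicity, read by sulforhodamine B assay, with a stated time of 48 h, tested at 10 uM; on this read-out higher numbers stand for a weaker effect at the one concentration tested and lower numbers for a stronger effect:

Compound 1 `COc1cc(-c2cc(/C=C/C(=O)c3ccc(N)cc3)[nH]n2)cc(OC)c1OC` gives -69%.
Compound 2 `COc1cc(-c2cc(/C=C/C(=O)c3ccc(Cl)c(Cl)c3)[nH]n2)cc(OC)c1OC` gives 63%.
Compound 3 `COc1ccc(C(=O)/C=C/c2cc(-c3cc(OC)c(OC)c(OC)c3)n[nH]2)cc1OC` gives -92%.

Among these three, compound 3 stands lowest, that is, it shows the strongest effect; the next nearest is compound 1, and compound 2 lies furthest away. Compound 4 `COc1cc(-c2cc(/C=C/C(=O)c3ccc(F)c(F)c3)[nH]n2)cc(OC)c1OC` differs from compound 3 in one place: 3,4-difluorophenyl in place of 3,4-dimethoxyphenyl on a carbonyl carbon.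

For the measured compounds named here, the steps that bear on this change both touch the same carbonyl carbon. Going a number 155 percentage points lower from compound 2 to compound 3 (beyond the scatter) shows that swapping a dihalogenated phenyl for the dimethoxyphenyl moved the number a long way down. Going a number 23 percentage points lower from compound 1 to compound 3 (beyond the scatter) was a smaller move in the same direction. Compound 4 reverses the direction of the first of these, putting a halogenated phenyl back in place of the dimethoxyphenyl, so a large upward step is expected, with a weaker effect than compound 3, though the data give no direct comparison of fluorine with chlorine. The expected step is a number 112 percentage points higher from compound 3 to compound 4 (beyond the scatter), and for compound 4 the estimate is 20%, in a range from -40% to 70%.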

Compound 4, a percentage reported as activity, at one concentration (the size of the read-out at that concentration, not a potency): -13%
Estimate against measurement, compound 4: 33 percentage points above; low and high end bracket the measured number.
By their numbers in this assay, from the lowest: compound 3; then compound 1; then compound 4; then compound 2.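

In this assay, the 3,4-difluorophenyl group on the carbonyl carbon lands in the middle of the series: the change gives a number 79 percentage points higher from compound 3 to compound 4 (beyond the scatter) and, against the dichlorinated partner, a number 76 percentage points lower from compound 2 to compound 4 (beyond the scatter). Two dihalogenated phenyl groups therefore do not behave alike at this place, so the label "halogenated" does not settle the outcome, and the 4-aminophenyl group also keeps the stronger effect, with a number 56 percentage points higher from compound 1 to compound 4 (beyond the scatter). No measurement available here explains why these groups differ.

The compounds shown leave open where a plain phenyl, a 4-fluorophenyl or a 3,4-dibromophenyl would fall on this scale. They also leave open whether a 4-hydroxyphenyl would stay close to the 4-aminophenyl group.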